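A few compounds are considered here, and "the series" means these few. Any claim that something is new, unique, unknown or untested is made for them only; others in the source may bear on it.

Compound 1 `CNCC1CCCc2cc(S(=O)(=O)c3ccccc3)ccc21`: in an assay on isolated protein for displacement of a labelled ligand from 5-hydroxytryptamine receptor 6 (Homo sapiens) (a higher number here means a weaker inhibitor, a lower number a stronger inhibitor), compound 1 gives 0.316 nM.
Compound 2 `O=C(NC[C@@H]1CCCc2cc(S(=O)(=O)c3cccc(F)c3)ccc21)[C@H]1CCCN1`: in this assay compound 2 gives 0.631 nM.

Compound 2 has the higher of the two numbers; its nearest neighbour is compound 1, and the gap between them lies within the scatter, so the two cannot be told apart. Compound 3 `CS(=O)(=O)NC[C@@H]1CCCc2cc(S(=O)(=O)c3cccc(F)c3)ccc21` differs from compound 2 in one place: methylsulfonyl in place of (pyrrolidin-2-yl)carbonyl on an amine nitrogen. Among the compounds with values here, no measured pair shows this change, so the account rests on expectation alone: the number is expected to rise by a moderate step, with a 9.5-fold higher number from compound 2 to compound 3 (0.98 log units; beyond the scatter) in this assay. Compound 3 is estimated at 6 nM, within a range from 1.5 nM to 30 nM.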

Compound 3, inhibition constant: 0.2 nM
Compound 3: middle estimate off by 30-fold (1.48 log units), on the high side; measured number outside the range, below it.
By their numbers in this assay, from the lowest: compounds 3, 1 and 2 (each within the scatter of the next, the first and the last beyond it).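

On the amine nitrogen, methylsulfonyl in place of (pyrrolidin-2-yl)carbonyl gives a 3.2-fold lower number from compound 2 to compound 3 (0.50 log units; beyond the scatter) in this assay. This position therefore accepts a group with fewer heavy atoms, no ring, no defined stereocentre and no hydrogen-bond donor, and the number still falls, so the (pyrrolidin-2-yl)carbonyl group is not needed for a low number in this pair. Nothing measured here accounts for the step.

As far as these compounds go, it remains open how an acetyl or a phenylsulfonyl group would read on the same nitrogen. From the compounds shown here alone, it is also open whether methylsulfonyl gives a similar step on a core without the fluorine.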